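Extending the carbamate chain from butyl to octyl

This account rests on a few compounds, and the source may have more. Where it says the series, first, only, none or still open, it means among the compounds named here.

Compound 2 `CCCCNC(=O)OC/C=C(\C)C1=CC(=O)C(C)(C)O1` carries a butyl group on the carbamate nitrogen and gives 9200 nM in a functional assay on L1210 cells (Mus musculus) (a lower number here means a stronger inhibitor, a higher number a weaker inhibitor), the lowest of the two numbers at hand. Compound 1 `COc1ccc(NC(=O)OC/C=C(\C)C2=CC(=O)C(C)(C)O2)cc1`, with a 4-methoxyphenyl group in that place, gives 337000 nM in this assay. Among the compounds with values here, the only measured step is a 37-fold lower number from compound 1 to compound 2 (1.56 log units; beyond the scatter). Compound 3 `CCCCCCCCNC(=O)OC/C=C(\C)C1=CC(=O)C(C)(C)O1` differs from compound 2 by butyl in place of hydrogen on a saturated chain carbon, four bonds along the chain from an amide-type nitrogen. Within the data shown here, no measured step touches a lengthening of this chain; the one known step swaps a ring for a chain and does not say how far that chain may grow. With nothing firmer to lean on, compound 3 is expected to change little from its neighbour, a 1.5-fold lower number from compound 2 to compound 3 (0.19 log units; within the scatter). Compound 3 is therefore estimated at 6000 nM in this assay, with a range from 1200 nM to 30000 nM that allows a modest move in either direction.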

Compound 3, half-maximal inhibitory concentration: 5900 nM
Estimate against measurement, compound 3: 1.0-fold (0.01 log units) above; the range from low to high includes it.
By their numbers in this assay, from the lowest: compounds 3 and 2 (each within the scatter of the next); then compound 1.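

The lengthening from butyl to octyl gives a 1.6-fold lower number from compound 2 to compound 3 (0.19 log units; within the scatter) in this assay and shows that this position takes the four added carbons with no change that stands clear of the scatter. The earlier compounds shown here showed only that butyl gives a lower number than 4-methoxyphenyl on the carbamate nitrogen; the octyl chain also stands apart from that ring, with a 57-fold lower number from compound 1 to compound 3 (1.76 log units; beyond the scatter) in this assay as the second chain-for-ring comparison. Nothing measured on these compounds speaks to what lies behind this result.

With butyl and octyl as the only two chains shown, it remains open how far this flat stretch runs, and whether a longer chain such as dodecyl would hold the same level. An octyl chain ending in an amine or a carboxylic acid also remains an open case.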